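This account rests on a few compounds, and the source may have more. Where it says the series, first, only, none or still open, it means among the compounds named here.

Three compounds have been measured in a functional assay on A549 cells (Homo sapiens) for antiproliferative activity, read by sulforhodamine B assay, with a stated time of 72 h; on this read-out lower numbers stand for stronger inhibition and higher numbers for weaker inhibition:

Compound 1, `COc1ncc(-c2ccc3ncnc(Nc4cnn(CCC(=O)O)c4)c3c2)cc1NS(C)(=O)=O`, gives 3840 nM.
Compound 2, `COc1ncc(-c2ccc3ncnc(Nc4ccc(OCCO)c(F)c4)c3c2)cc1NS(=O)(=O)c1ccc(F)cc1F`, gives 6640 nM.
Compound 3, `COc1ncc(-c2ccc3ncnc(Nc4cnn(CC(=O)O)c4)c3c2)cc1NS(=O)(=O)c1ccc(F)cc1F`, gives 5200 nM.

Compound 2 has the largest of the three numbers, but the gap to compound 3 lies within the scatter, and the gap to compound 1 lies within the scatter as well, so the three measured compounds cannot be told apart on this read-out.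

Compound 4, `COc1ncc(-c2ccc3ncnc(Nc4ccc(OCCO)nc4)c3c2)cc1NS(=O)(=O)c1ccc(F)cc1F`, differs from compound 2 in one place only: 6-(2-hydroxyethoxy)pyridin-3-yl in place of 3-fluoro-4-(2-hydroxyethoxy)phenyl on a nitrogen on an aromatic ring. Going by the values given here, the one measured step that touches this position is the exchange of the whole group on that nitrogen for a different ring type, and it was a 1.3-fold lower number from compound 2 to compound 3 (0.11 log units; within the scatter). Among the compounds with values here, no measured pair exchanges a phenyl ring for a pyridine ring while keeping the hydroxyethoxy chain, so that narrower change has no direct precedent here. Given that even the larger exchange at this position stayed within the scatter, the expectation for compound 4 is a step of about a 1.1-fold lower number from compound 2 to compound 4 (0.04 log units; within the scatter), not beyond the scatter in either direction. Compound 4 is therefore estimated at 6000 nM in this assay, with a range from 2800 nM to 13000 nM.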

Compound 4, half-maximal inhibitory concentration: 4120 nM
Estimate against measurement, compound 4: 1.5-fold (0.16 log units) above; measured number inside the range.
By their numbers in this assay, from the lowest: compounds 1, 4, 3 and 2 (each within the scatter of the next).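

In this assay, the new group 6-(2-hydroxyethoxy)pyridin-3-yl keeps the hydroxyethoxy chain of the group it replaces but has a nitrogen in the ring and no fluorine, and this narrower exchange gives a 1.6-fold lower number from compound 2 to compound 4 (0.21 log units; within the scatter). Set against the 1-(carboxymethyl)-1H-pyrazol-4-yl group, the same new group gives a 1.3-fold lower number from compound 3 to compound 4 (0.10 log units; within the scatter), so the three groups compared on this aromatic-ring nitrogen, with the rest of the molecule unchanged, now all lie within the scatter of one another, and neither a narrow nor a broad exchange has yet separated them. Nothing else at hand bears on this result.

Compound 4 gains the ring nitrogen and loses the fluorine in a single step, so the two changes cannot be separated; a plain 4-(2-hydroxyethoxy)phenyl group would be needed to tell them apart. Going by these compounds, it also remains open whether this position stays this flat with a different kind of chain on the ring, such as a dimethylaminoethoxy chain in place of the hydroxyethoxy chain.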